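The source may report more compounds than this note shows. Statements on the series, on what has been measured and on what is new or still open speak of the compounds shown alone.

Three compounds share one core and differ only in the group on the carbonyl carbon of the amide. Compound 1 `CCCCCCCCc1ccc(NC(=O)[C@H](N)CO)cc1` gives 5000 nM in an assay on isolated protein for inhibition of sphingosine kinase 1 (Homo sapiens), read by mobility shift assay; a lower number here means a stronger inhibitor, a higher number a weaker inhibitor. Compound 2 `CCCCCCCCc1ccc(NC(=O)[C@H](CO)NC)cc1` gives 2800 nM in this assay, and the step between them is a 1.8-fold lower number from compound 1 to compound 2 (0.25 log units; within the scatter). Compound 3 `CCCCCCCCc1ccc(NC(=O)[C@@H](N)[C@H](C)O)cc1` gives 1100 nM in this assay, the lowest number of the three, reached by a 4.5-fold lower number from compound 1 to compound 3 (0.66 log units; beyond the scatter) and by a 2.5-fold lower number from compound 2 to compound 3 (0.41 log units; beyond the scatter).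

Compound 4 `CCCCCCCCc1ccc(NC(=O)[C@H]2NC[C@@H](O)[C@@H]2O)cc1` has not yet been measured. Its difference from compound 3 is 3,4-dihydroxypyrrolidin-2-yl in place of 1-amino-2-hydroxypropyl on a carbonyl carbon. Among the measured compounds shown here, the steps that bear on this change are the two that also alter the group on the carbonyl carbon, namely a 4.5-fold lower number from compound 1 to compound 3 (0.66 log units; beyond the scatter) and a 2.5-fold lower number from compound 2 to compound 3 (0.41 log units; beyond the scatter), both modest in size. For the measured compounds named here, none of the measured steps closes a ring, so the change to compound 4 reaches beyond what the numbers cover. Since the measured steps stay modest, compound 4 is expected to move by about a 1.4-fold lower number from compound 3 to compound 4 (0.14 log units; within the scatter), a small gain at most. Compound 4 is therefore estimated at 800 nM in this assay, with a range from 250 nM to 2500 nM.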

Compound 4, half-maximal inhibitory concentration: 8300 nM
The estimate for compound 4 lay 10-fold (1.02 log units) below the measured number; the measured number lies above the stated range.
By their numbers in this assay, from the lowest: compound 3; then compounds 2, 1 and 4 (each within the scatter of the next, the first and the last beyond it).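

Closing the group on the carbonyl carbon into a 3,4-dihydroxypyrrolidin-2-yl ring gives up what the open chains had reached in this assay, with both the 1-amino-2-hydroxypropyl group (a 7.5-fold higher number from compound 3 to compound 4 (0.88 log units; beyond the scatter)) and the 2-hydroxy-1-(methylamino)ethyl group (a 3.0-fold higher number from compound 2 to compound 4 (0.47 log units; beyond the scatter)) ahead of the ring. Against the 1-amino-2-hydroxyethyl group the ring shows no clear difference (a 1.7-fold higher number from compound 1 to compound 4 (0.22 log units; within the scatter)), so at this position the first ring shown brings no gain over any of the open chains. No measurement at hand explains this result.

The compounds shown do not separate the effect of the ring from that of its hydroxyl groups or their stereocentres. A plain pyrrolidin-2-yl group without hydroxyl groups, or a piperidin-2-yl ring, would be needed to tell these apart.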